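The source may hold more compounds than are shown below. What is called first, only, known or untested is meant among the compounds shown, and "the series" means these compounds.

Measured compounds in an ADME assay on microsomes from liver (Homo sapiens) for metabolic stability, tested at 2.5 uM; a lower number here means slower removal, a higher number faster removal of the compound:
- compound 1 `O=S(=O)(c1ccc(F)c(F)c1)c1cnc2cc(F)ccc2c1-c1cccc(F)c1`: 0.6 mL/min
- compound 2 `COc1cccc(-c2c(S(=O)(=O)c3ccc(F)c(F)c3)cnc3cc(F)ccc23)c1`: 1.77 mL/min

Compound 2 stands highest of the two numbers in this assay; its nearest neighbour is compound 1, reached by a 3.0-fold higher number from compound 1 to compound 2 (0.47 log units; beyond the scatter) in the other direction. That single step, methoxy in place of fluoro on an aromatic carbon, is the only one so far, and it is a modest one beyond the scatter.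

Compound 3 `O=S(=O)(c1ccc(F)c(F)c1)c1cnc2cc(F)ccc2c1-c1ccccc1F` is not yet measured. It differs from compound 2 by 2-fluorophenyl in place of 3-methoxyphenyl on an aromatic carbon. The change takes out the 3-methoxyphenyl that separates compound 2 from compound 1 and puts a fluorophenyl back in, so the step from compound 1 to compound 2 bears on it most directly, though it ran in the opposite sense and the fluorine now sits at a different position of the ring, for which no comparison exists. A step downward in this assay of roughly the size seen between compound 1 and compound 2 is therefore expected, though with less confidence than if the same fluorophenyl returned; the expected step is a 2.2-fold lower number from compound 2 to compound 3 (0.34 log units; beyond the scatter). Compound 3 is thus estimated at 0.8 mL/min in this assay, with a range from 0.4 mL/min to 1.6 mL/min.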

Compound 3, intrinsic clearance in a liver preparation (reported as CLH), per the amount of preparation that the assay uses: 0.79 mL/min
The estimate for compound 3 lay 1.0-fold (0.01 log units) above the measured number, and the stated range covers the measured number.
By their numbers in this assay, from the lowest: compounds 1 and 3 (each within the scatter of the next); then compound 2.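

Notes on the aromatic carbon opposite the ring nitrogen, read in this assay: 2-fluorophenyl in place of 3-fluorophenyl gives a 1.3-fold higher number from compound 1 to compound 3 (0.12 log units; within the scatter) and so leaves these two fluorophenyl isomers indistinguishable in this read-out. 2-fluorophenyl in place of 3-methoxyphenyl gives a 2.2-fold lower number from compound 2 to compound 3 (0.35 log units; beyond the scatter) and shows that a second fluorophenyl also stands apart from the 3-methoxyphenyl of compound 2, which is now separated from both fluorophenyl compounds by steps beyond the scatter. No accompanying measurement bears on these results, so the numbers remain unexplained.

As far as these compounds go, it remains open whether the gap belongs to methoxy as such or to its ring position, since 2-methoxyphenyl does not appear here, and how an unsubstituted phenyl or a phenyl carrying an amine or a carboxylic acid would read in this assay. The rest of the core is the same in compound 1, compound 2 and compound 3, so these steps say nothing about how the change at this position would read on a different core.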